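Thiophene in Place of Iodine on Two Related Cores

The compounds below may be only part of what the source reports. "The series", "measured", "known", "first", "only" and "open" are said of these compounds alone.

Compound 1 has the structure `Cc1cc(I)c2ncc(CSCCc3ccccc3)n2c1`. In an ADME assay on HEL cells (Homo sapiens) for cytotoxicity, with a stated time of 3 days (on this read-out lower numbers stand for higher toxicity in this test and higher numbers for lower toxicity in this test), compound 1 reaches only the limit > 50 ug/mL, not a number. Compound 2, `Cc1cc(-c2cccs2)c2ncc(CSCCc3ccccc3)n2c1`, differs from compound 1 by thiophen-2-yl in place of iodo on an aromatic carbon. In this assay compound 2 likewise stops at the limit > 50 ug/mL. The step that the two limits leave unreadable from compound 1 to compound 2 is therefore not readable between two limits. Compound 3, `Cc1cc(I)cn2c(CSCCc3ccccc3)cnc12`, is built from the same atoms as compound 1, joined differently; the difference between the two cores is not broken down here. In this assay compound 3 again gives the limit > 50 ug/mL. Compound 4, `Cc1cc(-c2cccs2)cn2c(CSCCc3ccccc3)cnc12`, is not yet measured and differs from compound 3 by thiophen-2-yl in place of iodo on an aromatic carbon. This is the same kind of change as that from compound 1 to compound 2, though the place is not identical: in compound 1 it is ortho to a fused ring, in compound 3 para to a fused ring. All three values sit at the limit of > 50 ug/mL in this assay, at which 3 of the 3 values shown sit. Because the limit of > 50 ug/mL in this assay, at which 3 of the 3 values shown sit, holds all three measured compounds, the expected step that the limit leaves unreadable from compound 3 to compound 4 is estimated to be small, and compound 4 is expected to give about 60 ug/mL in this assay.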

Compound 4, half-maximal cytotoxic concentration: 32 ug/mL
Estimate against measurement, compound 4: 1.9-fold (0.27 log units) above, within the range that was stated.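

In this assay, among these compounds, thiophen-2-yl in place of iodo on the core of compound 3 gives an at least 1.5-fold lower number from compound 3 to compound 4 (0.19 log units; that floor lies within the scatter), and compound 4, at 32 ug/mL, is the only one of the four compounds to give a number rather than a limit. The same change on the core of compound 1 offers no size to set beside this step, because the step there cannot be read, with both partners stopping at a limit: the limit of > 50 ug/mL in this assay, at which 3 of the 4 values shown sit. The result therefore neither shows that the change carries from one core to the other nor shows that it fails to, and the step on the core of compound 3 is itself only a floor.

Going by these compounds, it remains open whether the number for compound 4 is particular to thiophen-2-yl or would appear with other groups at that place. An amine or a carboxylic acid in place of iodo on each core would bear on this question.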